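A few compounds are considered here, and "the series" means these few. Any claim that something is new, unique, unknown or untested is made for them only; others in the source may bear on it.

Within the data shown here, compound 1 `Clc1cc(Cl)cc(CO[C@H]2CCCN(Cc3ccccn3)[C@H]2c2ccccc2)c1` and compound 2 `O=C(O)c1cncc(CN2CCC[C@H](O[C@H](CO)c3cc(Cl)cc(Cl)c3)[C@@H]2c2ccccc2)c1` are the two measured members of this set. In an assay on isolated protein for activation of cGMP-dependent protein kinase 1 (Homo sapiens), read by ADP-Glo, with stated times of 120 min and 40 min (on this read-out lower numbers stand for an effect already at smaller amounts and higher numbers for an effect only at larger amounts of compound), compound 1 gives > 200000 nM, which is a limit of the assay rather than a number. In this assay compound 2 gives 34000 nM. Compound 1 stands at the limit of > 200000 nM in this assay, at which 1 of the 2 values shown sits, so only its floor is known, and the two compounds differ in more than one place, so their values are simply two readings side by side. Compound 3 `Clc1cc(Cl)cc(CO[C@H]2CCCN(Cc3cccnc3)[C@H]2c2ccccc2)c1` keeps the same atoms as compound 1 but joins them differently: pyridin-3-yl in place of pyridin-2-yl on a saturated chain carbon bound to an amine nitrogen in a ring. Among the measured compounds shown here, no measured step of this kind exists here, and with compound 1 sitting at a limit, no change beyond the scatter is expected; the expected step in this assay is written as an at least 1.3-fold lower number from compound 1 to compound 3 (0.12 log units; that floor lies within the scatter). For compound 3 the estimated value in this assay is 150000 nM, with a range from 40000 nM to 500000 nM.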

Compound 3, half-maximal effective concentration: 112000 nM
For compound 3 the middle estimate is 1.3-fold (0.13 log units) above the measured one; low and high end bracket the measured number.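

Among these compounds, replacing pyridin-2-yl with pyridin-3-yl on a saturated chain carbon bound to an amine nitrogen in a ring gives the first step that can be read at this position: in this assay it is an at least 1.7-fold lower number from compound 1 to compound 3 (0.25 log units; that floor lies within the scatter). The step is only a floor because compound 1 stands at a limit of the assay: the limit of > 200000 nM in this assay, at which 1 of the 3 values shown sits. With that floor inside the scatter, the pair does not establish that this change matters, though compound 3 gives a number where compound 1 gives only a limit.

On these data alone, the true size of the step stays open, as does the reading that pyridin-4-yl or a longer chain in place of the (pyridin-3-yl)methyl group would give. Also open, as far as these compounds go, is how much a carboxylic acid on the pyridin-3-yl group would contribute on the core of compound 3 alone.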